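Adding a Methoxy to the Phenyl Ring of Compound 2

The source may hold more compounds than are shown below. What is called first, only, known or untested is meant among the compounds shown, and "the series" means these compounds.

Compound 2 `O=c1cc(-c2ccccc2)oc2ccc(OC/C(=N/O)c3ccccc3)cc12` gives 700000 nM in a functional assay on SK-HEP1 cells (Homo sapiens) for antiproliferative activity (a lower number here means a stronger inhibitor of growth, a higher number a weaker inhibitor of growth), which is the lowest of the two numbers recorded so far. Its nearest neighbour, compound 1 `CO/N=C(\C)COc1ccc2oc(-c3ccccc3)cc(=O)c2c1`, gives 800000 nM in this assay, and the two numbers lie within the scatter of each other. Among the compounds with values here, the only measured step, a 1.1-fold lower number from compound 1 to compound 2 (0.06 log units; within the scatter), therefore shows no real movement.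

Compound 3 `COc1ccc(/C(COc2ccc3oc(-c4ccccc4)cc(=O)c3c2)=N\O)cc1` differs from compound 2 by methoxy in place of hydrogen on an aromatic carbon; cut one bond further out, the change reads phenyl to 4-methoxyphenyl. Within the data shown here, no measured step involves a methoxy group, so the single recorded step is the only guide, and it was within the scatter. On that basis the step from compound 2 to compound 3 is expected to be small, a 1.2-fold lower number from compound 2 to compound 3 (0.07 log units; within the scatter), with no direction beyond the scatter. Compound 3 is accordingly expected to give about 600000 nM in this assay, within a range from 250000 nM to 1500000 nM.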

Compound 3, concentration for 50% growth inhibition: 800000 nM
For compound 3 the middle estimate is 1.3-fold (0.12 log units) below the measured one; the range from low to high includes it.
By their numbers in this assay, from the lowest: compounds 2, 1 and 3 (each within the scatter of the next).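

In this assay, methoxy in place of hydrogen on an aromatic carbon, para to a large group, gives a 1.1-fold higher number from compound 2 to compound 3 (0.06 log units; within the scatter). Within the data shown here, the earlier step had exchanged a whole group on the saturated chain carbon, whereas this one is the first to test a substituent on the phenyl ring of compound 2, and phenyl and 4-methoxyphenyl cannot be told apart here. No supporting measurement bears on this result.

On these data alone, it remains open whether a different group at this same place, such as an amine, a carboxylic acid or a longer chain, would give a step beyond the scatter. The compounds shown also leave open whether methoxy on another carbon of this ring would do so.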